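Removing the methyl from an aryl ether on a quinolone core

The source may hold more compounds than are shown below. What is called first, only, known or untested is meant among the compounds shown, and "the series" means these compounds.

Compound 1 `COc1ccc2[nH]c(-c3ccccc3F)cc(=O)c2c1OC` gives > 20000 nM in a functional assay on Hep 3B2 cells (Homo sapiens) for cytotoxicity, read by MTT assay, with a stated time of 48 h; on this read-out higher numbers stand for weaker inhibition and lower numbers for stronger inhibition.
Compound 2 `COc1ccc2[nH]c(-c3cccc(F)c3)cc(=O)c2c1OC` gives 2600 nM in this assay.
Compound 3 `COc1ccc2[nH]c(-c3ccc(F)cc3)cc(=O)c2c1OC` gives > 20000 nM in this assay.

Compound 1 sits at a limit of this assay, so only a bound, not a number, is known for it. Compound 3 also sits at a limit, and compound 2 alone yields a number, which sets it apart from the other two, as the steps of an at least 7.6-fold lower number from compound 1 to compound 2 (0.88 log units; beyond the scatter) and an at least 7.6-fold higher number from compound 2 to compound 3 (0.88 log units; beyond the scatter) show; the step that the two limits leave unreadable from compound 1 to compound 3 stays unreadable for the reason given in the limit of > 20000 nM in this assay, at which 2 of the 3 values shown sit.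

Compound 4 `COc1ccc2[nH]c(-c3ccccc3F)cc(=O)c2c1O` differs from compound 1 by hydrogen in place of methyl on an oxygen on an aromatic ring. None of the three measured steps touches this ether oxygen; all of them move a fluorine around the pendant phenyl ring and leave the two methoxy groups of the core untouched. The data therefore give no measured guide to the size or direction of the change from methoxy to hydroxy in this assay.

With compound 1 already at a limit, compound 4 is expected to give 20000 nM, within a range of 7000 nM to 60000 nM. The estimated step of a number no higher from compound 1 to compound 4 (the limit leaves the size open) expresses no change beyond the scatter, and a further limit reading is considered the most likely outcome.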

Compound 4, half-maximal inhibitory concentration: 50 nM
The estimate for compound 4 lay 400-fold (2.60 log units) above the measured number; the whole stated range lies above it.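

Methoxy to hydroxy on this oxygen on an aromatic ring is the first change shown that touches the core rather than the pendant phenyl ring, and in this assay it gives an at least 400-fold lower number from compound 1 to compound 4 (2.60 log units; beyond the scatter). The true size of this step stays open on the upper side, as the value of compound 1 is a limit and not a number: the limit of > 20000 nM in this assay, at which 2 of the 4 values shown sit.

The earlier compounds shown here showed only that moving the fluorine around the pendant ring could bring a number into reach, whereas this step shows that losing a single methyl from the core's ether brings a compound that keeps the 2-fluorophenyl group off the limit.

On these data alone, whether the same change carries over to the 3-fluorophenyl of compound 2 or the 4-fluorophenyl of compound 3, and whether the other methoxy group of the core responds in the same way, remains open. As far as these compounds go, it is also open what a larger group on this oxygen, such as an ethyl chain or an acetyl group, or an amine in place of the hydroxy, would do in this assay.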